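Swapping a Thiophene for a Pyridine on a Shared Core

A few compounds are considered here, and "the series" means these few. Any claim that something is new, unique, unknown or untested is made for them only; others in the source may bear on it.

Three compounds share a core that carries a 3-hydroxyphenyl group and a chlorophenyl group. Compound 1 `Oc1cccc(-c2cc(-c3ccncc3)nc(-c3cccc(Cl)c3)c2)c1` has no result to show: in a functional assay on DU-145 cells (Homo sapiens) for cytotoxicity, read by CCK-8 assay and cell counting, with a stated time of 2 days (on this read-out higher numbers stand for weaker inhibition and lower numbers for stronger inhibition), compound 1 is recorded as "not determined" (no result reported). Going by the values given here, compound 2 `Oc1cccc(-c2cc(-c3ccc(Cl)cc3)nc(-c3ccsc3)c2)c1` is the only compound with a number: in this assay compound 2 gives 11600 nM, so it stands alone and cannot be placed above or below anything. Compound 3 `Oc1cccc(-c2cc(-c3ccncc3)nc(-c3ccc(Cl)cc3)c2)c1` differs from compound 2 in one place: pyridin-4-yl in place of thiophen-3-yl on an aromatic carbon. Among the compounds with values here, no step between two measured compounds is available, so the effect of this kind of change has not been seen here. One aromatic ring replaces another of roughly the same shape, and in this assay no step beyond the usual scatter is expected, in either direction. Compound 3 is therefore expected to give about 10000 nM in this assay, within a range from 3000 nM to 35000 nM. The expected step is a 1.2-fold lower number from compound 2 to compound 3 (0.06 log units; within the scatter).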

Compound 3, half-maximal inhibitory concentration: 2510 nM
The estimate for compound 3 lay 4.0-fold (0.60 log units) above the measured number, and the stated range ends above it.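

Going by these compounds alone, this is the first step that can be read at this position: in this assay, pyridin-4-yl in place of thiophen-3-yl gives a 4.6-fold lower number from compound 2 to compound 3 (0.66 log units; beyond the scatter) and so shows that one aromatic ring does not simply stand in for the other here. The two groups have the same hydrogen-bond donor and acceptor counts and no net charge, so those counts do not separate them, while ring size and hetero atom, nitrogen against sulfur, do differ. The data shown do not say which of these differences matters, or why the number falls.

A plain phenyl group at this position would help separate the role of the ring nitrogen from that of ring size. On these data alone, whether pyridin-3-yl, or an amine added to the pyridine ring, would move the number further also remains open.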